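The source may report more compounds than this note shows. Statements on the series, on what has been measured and on what is new or still open speak of the compounds shown alone.

Measured compounds in the series:

compound 1, `COc1ccc(-c2cn(C[C@H](O)[C@H]3OC(=O)C(OCc4ccccc4)=C3OCc3ccccc3)nn2)cc1` — 46400 nM
compound 2, `COc1ccccc1-c1cn(C/C=C2\OC(=O)C(OCc3ccccc3)=C2OCc2ccccc2)nn1` — a limit, > 100000 nM

Going by the values given here, in a functional assay on HepG2 cells (Homo sapiens) for antiproliferative activity, read by MTT assay, with a stated time of 72 h (a higher number here means a weaker inhibitor, a lower number a stronger inhibitor), compound 1 gives 46400 nM, the only numerical value shown so far in the set. For compound 2 the result in this assay is a limit, > 100000 nM, and not a number. Among the compounds with values here, the set thus holds one number and (the limit of > 100000 nM in this assay, at which 1 of the 2 values shown sits); no pair of measured compounds differs in a single place, so no measured step is available.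

Compound 3, `CCCCCCCCCCc1cn(C[C@H](O)[C@H]2OC(=O)C(OCc3ccccc3)=C2OCc2ccccc2)nn1`, is the next member to be tested in this assay. It differs from compound 1 by decyl in place of 4-methoxyphenyl on an aromatic carbon. Within the data shown here, with no measured step to rest on, the expectation for the step from compound 1 to compound 3 is set as a 1.5-fold lower number from compound 1 to compound 3 (0.19 log units; within the scatter), a shift not clearly beyond the scatter and, if anything, toward a stronger inhibitor. Compound 3 is therefore expected at 30000 nM, with a range from 8000 nM to 100000 nM.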

Compound 3, half-maximal inhibitory concentration: 12200 nM
Compound 3: middle estimate off by 2.5-fold (0.39 log units), on the high side, and the stated range covers the measured number.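

In this assay the series now has its first measured step, on replacing 4-methoxyphenyl with decyl on an aromatic carbon of the five-membered aromatic ring with 3 nitrogen (a 3.8-fold lower number from compound 1 to compound 3 (0.58 log units; beyond the scatter)). The position therefore accepts a chain with no ring and no hydrogen-bond acceptor in place of the aromatic group, and the step runs toward a stronger inhibitor, so neither the six-membered aromatic ring nor the methoxy oxygen is required for activity here. No measurement shown bears on the cause of this step.

On these data alone, whether a shorter chain such as hexyl or a longer chain such as dodecyl moves the number further remains open. Also open, as far as these compounds go, is how a decyl chain ending in an amine or a carboxylic acid would compare with compound 3.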